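Smaller aryl swap on a shared imidazopyrazine-benzimidazole core

The source may hold more compounds than are shown below. What is called first, only, known or untested is meant among the compounds shown, and "the series" means these compounds.

Compound 1 `c1ccc(-c2cn3ccnc3c(-c3ccc4ncn(C5CCCCC5)c4c3)n2)cc1` gives 36.8% in a functional assay on 786-0 cells (Homo sapiens) for inhibition, read by sulforhodamine B assay, with a stated time of 48 h, tested at 10 uM; on this read-out higher numbers stand for more inhibition at the one concentration tested (going by the name of the read-out) and lower numbers for less inhibition.
Compound 2 `O=Cc1ccc(-c2cn3ccnc3c(-c3ccc4ncn(C5CCCCC5)c4c3)n2)cc1` gives 46.7%.
Compound 3 `c1ccc2c(-c3cn4ccnc4c(-c4ccc5ncn(C6CCCCC6)c5c4)n3)cccc2c1` gives 6.33%.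

Compound 2 gives the highest number of the three in this assay, with compound 1 closest, a number 9.9 percentage points higher from compound 1 to compound 2 (within the scatter), and compound 3 furthest, a number 40.4 percentage points lower from compound 2 to compound 3 (beyond the scatter). The unmeasured compound 4 `c1cn2cc(-c3ccsc3)nc(-c3ccc4ncn(C5CCCCC5)c4c3)c2n1` differs from compound 2 by thiophen-3-yl in place of 4-formylphenyl on an aromatic carbon. Among the measured compounds shown here, the only steps that bear on this are a number 30.5 percentage points lower from compound 1 to compound 3 (beyond the scatter) and a number 40.4 percentage points lower from compound 2 to compound 3 (beyond the scatter), both large losses when a bigger aryl replaces phenyl or 4-formylphenyl; removing the formyl alone, read backwards from a number 9.9 percentage points higher from compound 1 to compound 2 (within the scatter), costs nothing beyond the scatter. Since thiophen-3-yl is smaller than both, only a small downward step is expected, a number 10.7 percentage points lower from compound 2 to compound 4 (beyond the scatter), barely beyond the scatter. Compound 4 is therefore estimated at 36%, within 16% to 56%.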

Compound 4, a percentage reported as inhibition, at one concentration (the size of the read-out at that concentration, not a potency): 6.35%
Compound 4: middle estimate off by 29.7 percentage points, on the high side; the measured number lies below the stated range.
By their numbers in this assay, from the lowest: compounds 3 and 4 (each within the scatter of the next); then compounds 1 and 2 (each within the scatter of the next).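

The thiophen-3-yl swap costs about as much as the naphthalen-1-yl swap in this assay: there is a number 40.4 percentage points lower from compound 2 to compound 4 (beyond the scatter) and a number 30.5 percentage points lower from compound 1 to compound 4 (beyond the scatter), while a number 0 percentage points higher from compound 3 to compound 4 (within the scatter). At this position, then, the number does not follow group size alone, since the five-membered ring and the fused naphthalen-1-yl both fall well short of phenyl and 4-formylphenyl. Nothing measured here explains this.

As far as these compounds go, it remains open whether a pyridinyl ring would retain the number of phenyl, and whether a phenyl bearing an amine or a carboxylic acid in place of the formyl would match compound 2.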